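Amide aryl swap on a pyrazole urea-to-amide series

A few compounds are considered here, and "the series" means these few. Any claim that something is new, unique, unknown or untested is made for them only; others in the source may bear on it.

Measured compounds:
- compound 1 `COc1cc(Cl)cc(-c2nn(-c3cccc(NC(=O)Nc4cccc(C(F)(F)F)c4)c3)cc2-c2ccncc2)c1` with 5.44%
- compound 2 `COc1cc(Cl)cc(-c2nn(-c3cccc(NC(=O)c4ccc(Cl)c(Cl)c4)c3)cc2-c2ccncc2)c1` with 63.9%

In a functional assay on ACHN cells (Homo sapiens) for inhibition, read by sulforhodamine B assay, with a stated time of 48 h, tested at 10 uM (a lower number here means a stronger effect, a higher number a weaker effect of the compound at the concentration tested), compound 1 gives 5.44%, and compound 2 gives 63.9%. Compound 2 therefore stands at the weaker end of the two numbers shown, with compound 1 the only neighbour, its step being a number 58.5 percentage points higher from compound 1 to compound 2 (beyond the scatter). That single step changes two things at once, the urea to amide linkage and the aryl group, so it does not separate the two.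

Compound 3 `COc1cc(Cl)cc(-c2nn(-c3cccc(NC(=O)c4cccc(C(F)(F)F)c4)c3)cc2-c2ccncc2)c1` has not yet been measured in this assay. It keeps the amide of compound 2 but carries the change (3-(trifluoromethyl)phenyl in place of 3,4-dichlorophenyl on a carbonyl carbon). For the measured compounds named here, no measured step isolates this exchange: the step from compound 1 to compound 2 is the only one available, and it bears on it only in part, since compound 3 shares the aryl of compound 1 and the carbonyl linkage of compound 2. An expectation is accordingly wide. Compound 3 is estimated at 35%, with a range from 5% to 75%, which would mean an expected step of a number 28.9 percentage points lower from compound 2 to compound 3 (beyond the scatter).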

Compound 3, a percentage reported as activity, at one concentration (the size of the read-out at that concentration, not a potency): 48.1%
For compound 3 the middle estimate is 13.1 percentage points below the measured one; the measured number falls inside the stated range.
By their numbers in this assay, from the lowest: compound 1; then compound 3; then compound 2.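

Compound 3 separates what the earlier step had joined: with the 3-(trifluoromethyl)phenyl group kept, replacing the urea with the amide gives a number 42.7 percentage points higher from compound 1 to compound 3 (beyond the scatter) in this assay, so the linkage alone carries a large change in this read-out. With the amide kept, exchanging the aryl group on the carbonyl carbon gives a number 15.8 percentage points lower from compound 2 to compound 3 (beyond the scatter), which shows that this position still responds once the urea is gone, and that among these three compounds the aryl exchange weighs less than the change of linkage. Nothing at hand offers an explanation for either step.

The compounds shown leave open whether the two changes act independently, since a urea carrying the 3,4-dichlorophenyl group, which would show whether this aryl exchange has the same size on a urea as on an amide, does not stand among them. They also do not tell how this assay would read with a carboxylic acid or an amine on the aryl ring of the amide, or with a longer chain in place of that ring.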